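The source may hold more compounds than are shown below. What is called first, only, known or untested is meant among the compounds shown, and "the series" means these compounds.

Compound 1, `Cc1nnc(-c2cccc(-c3ccc(C(=O)N(Cc4cccc(OCCCCCC(=O)O)c4)C(C)C)cc3)c2)o1`. In an ADME assay on Raji cells (Homo sapiens) for cytotoxicity, read by CellTiter-Glo and resazurin assay, with a stated time of 72 h (on this read-out lower numbers stand for an effect already at smaller amounts and higher numbers for an effect only at larger amounts of compound), compound 1 gives > 26000 nM, which is a limit of the assay rather than a number.
Compound 2, `COc1cc(OC)cc(-c2ccc(C(=O)N(Cc3cccc(OCCCCCC(=O)O)c3)C(C)C)cc2)c1`. In this assay compound 2 gives > 26000 nM, again a limit and not a number.

Compound 2 therefore stands at the upper edge of what this assay reports, with no effect seen up to that amount. Going by the values given here, the only step among the measured pair, a step that the two limits leave unreadable from compound 1 to compound 2, cannot be sized, since both values sit at the limit of > 26000 nM in this assay, at which 2 of the 2 values shown sit. Compound 3, `CC(C)N(Cc1cccc(OCCCCCC(=O)O)c1)C(=O)c1ccc(-c2cccc(OC(F)(F)F)c2)cc1`, differs from compound 2 by 3-(trifluoromethoxy)phenyl in place of 3,5-dimethoxyphenyl on an aromatic carbon. Among the compounds with values here, no measured step speaks for or against a change here, so the plain expectation is that compound 3 also shows no effect within the range of this assay. Compound 3 is thus expected to give 26000 nM, within 8000 nM to 60000 nM, most likely reported as a limit, and the expected step of a number no higher from compound 2 to compound 3 (the limit leaves the size open) is none beyond the scatter.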

Compound 3, half-maximal effective concentration: > 26000 nM
Compound 3 gave a limit, no number (the forecaster's own chance of this, stated with the estimate: 75%); the middle value sits exactly at the limit.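

Going by these compounds alone, compound 3 gives a limit and not a number, as do compound 1 and compound 2, so no step among the three can be read: the limit of > 26000 nM in this assay, at which 3 of the 3 values shown sit. The compounds shown leave open whether they truly differ in this assay, and whether any change at this place would give a readable number.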